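Cytotoxicity of benzothiazole anilines and a methoxy analogue

The source may hold more compounds than are shown below. What is called first, only, known or untested is meant among the compounds shown, and "the series" means these compounds.

Compound 1 `c1ccc(-c2ccc(Cn3cncc3CNc3ccc(-c4nc5ccccc5s4)c(-c4ccccc4)c3)cc2)cc1` — a toxicity assay on NIH3T3 cells (Mus musculus) for cytotoxicity, read by resazurin assay; on this read-out lower numbers stand for an effect already at smaller amounts and higher numbers for an effect only at larger amounts of compound: compound 1 gives > 1000 nM
Compound 2 `CCc1ccc(Cn2cncc2CNc2ccc(-c3nc4ccccc4s3)c(-c3ccccc3)c2)cc1` — in this assay compound 2 gives > 1000 nM
Compound 3 `Cc1ccccc1-c1ccc(Cn2cncc2CNc2ccc(-c3nc4ccccc4s3)c(-c3ccccc3)c2)cc1` — in this assay compound 3 gives > 1000 nM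

Compound 1 stands only at a limit of this assay, not at a number. The value of compound 2 is likewise a limit. The value of compound 3 is a limit as well. The steps a step that the two limits leave unreadable from compound 1 to compound 2, a step that the two limits leave unreadable from compound 1 to compound 3 and a step that the two limits leave unreadable from compound 2 to compound 3 therefore cannot be sized, because of the limit of > 1000 nM in this assay, at which 3 of the 3 values shown sit.

Compound 4 `COc1ccc(NCc2cncn2Cc2ccc(-c3ccccc3)cc2)cc1-c1ccccc1` is the next compound. Its difference from compound 1 is methoxy in place of 1,3-benzothiazol-2-yl on an aromatic carbon. For the measured compounds named here, none of the three measured steps touches this part of the shared core; each of them alters a group on the other end of the molecule, so no measured step bears directly on the change from compound 1 to compound 4. What the three limits show is that the shared core of compound 1, compound 2 and compound 3 shows its effect in this assay only at larger amounts, whatever sits on the benzylic aryl ring.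

On that basis the step of a number no higher from compound 1 to compound 4 (the limit leaves the size open) is expected to stay within the scatter. Compound 4 is estimated at 1000 nM, in the range 300 nM to 3000 nM, most likely reported again only as a limit.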

Compound 4, half-maximal effective concentration: > 1000 nM
Compound 4: only a limit was reported; the forecaster's own chance of this, stated with the estimate: 75%; the middle value lies on the limit itself.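

In this assay compound 4 gives > 1000 nM, which is a limit and not a number. No step can be read between compound 1 and compound 4, because both stand at the same limit: the limit of > 1000 nM in this assay, at which 4 of the 4 values shown sit.

The compounds shown leave open at what amount any of the four would show its effect in this assay, and whether methoxy in place of 1,3-benzothiazol-2-yl changes that amount at all.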